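The source may hold more compounds than are shown below. What is called first, only, known or untested is meant among the compounds shown, and "the series" means these compounds.

In a functional assay on A549 cells (Homo sapiens) for antiproliferative activity, read by MTT assay, with a stated time of 72 h (on this read-out higher numbers stand for weaker inhibition and lower numbers for stronger inhibition), compound 2 `O=C(Nc1ccc(Cl)c(-c2nnc3c(Cl)cccn23)c1)c1ccc(Cl)cc1Cl` gives 61300 nM. Compound 1 `Cc1nc(C(=O)Nc2ccc(Cl)c(-c3nnc4c(Cl)cccn34)c2)cs1` reaches only a limit of this assay, > 100000 nM. Compound 3 `CS(=O)(=O)c1cccc(C(=O)Nc2ccc(Cl)c(-c3nnc4c(Cl)cccn34)c2)c1` likewise reaches only a limit, > 100000 nM. Compound 3 therefore stands at the point where most of the values gather, namely (the limit of > 100000 nM in this assay, at which 2 of the 3 values shown sit). Compound 4 `O=C(Nc1ccc(Cl)c(-c2nnc3c(Cl)cccn23)c1)c1ccccn1` differs from compound 3 by pyridin-2-yl in place of 3-(methylsulfonyl)phenyl on a carbonyl carbon. The measured steps that bear on such a swap of the aryl group on the carbonyl carbon are an at least 1.6-fold higher number from compound 2 to compound 3 (0.21 log units; that floor lies within the scatter) and a step that the two limits leave unreadable from compound 1 to compound 3, neither of which shows a movement that can be read as real. The step expected here is a number no higher from compound 3 to compound 4 (the limit leaves the size open), that is, nothing beyond the scatter. Compound 4 is accordingly estimated to give 100000 nM, between 30000 nM and 300000 nM.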

Compound 4, half-maximal inhibitory concentration: > 100000 nM
Compound 4: no number, only a limit; the forecaster's own chance of this, stated with the estimate: 70%; the middle value sits exactly at the limit.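

In this assay compound 4, with pyridin-2-yl on the carbonyl carbon, gives > 100000 nM, which is a limit and not a number. Going by these compounds alone, the one step that can be read is an at least 1.6-fold higher number from compound 2 to compound 4 (0.21 log units; that floor lies within the scatter), while the steps linking compound 4 to compound 1 and compound 3 cannot be read. A smaller group with a ring nitrogen therefore brings no readable change at this position, and the values gather further at one point: the limit of > 100000 nM in this assay, at which 3 of the 4 values shown sit.

Still open, from the compounds shown here alone, is whether an amine or a carboxylic acid on this ring, or a longer chain in its place, would bring the number clearly below the limit. Within the data shown here, with compound 2 the only one giving a number, the other compounds cannot be ranked.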